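Sulfonylquinoxaline anilines: ring-amino position swap in KB cells

The source may report more compounds than this note shows. Statements on the series, on what has been measured and on what is new or still open speak of the compounds shown alone.

Compound 1 `Cc1ccc(S(=O)(=O)c2nc3ccccc3nc2Nc2ccc(N)cc2)cc1` carries a 4-aminophenyl on the ring nitrogen and a methyl on the sulfonyl-bearing ring. In a functional assay on KB cells (Homo sapiens) for cytotoxicity, read by MTT assay, with a stated time of 72 h (on this read-out lower numbers stand for stronger inhibition and higher numbers for weaker inhibition), compound 1 gives 5630 nM. Compound 2 `Cc1ccc(S(=O)(=O)c2nc3ccccc3nc2Nc2cccc(N)c2)cc1` differs by 3-aminophenyl in place of 4-aminophenyl on a nitrogen on an aromatic ring; in this assay compound 2 gives 10600 nM, which is a 1.9-fold higher number from compound 1 to compound 2 (0.27 log units; within the scatter). Compound 3 `COc1ccc(S(=O)(=O)c2nc3ccccc3nc2Nc2ccc(N)cc2)cc1` differs from compound 1 by methoxy in place of methyl on an aromatic carbon; in this assay compound 3 gives 17800 nM, which is a 3.2-fold higher number from compound 1 to compound 3 (0.50 log units; beyond the scatter). Compound 2 and compound 3 stand within the scatter of one another.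

Compound 4 `COc1ccc(S(=O)(=O)c2nc3ccccc3nc2Nc2cccc(N)c2)cc1` is not yet measured and differs from compound 3 by 3-aminophenyl in place of 4-aminophenyl on a nitrogen on an aromatic ring. This is the same change as from compound 1 to compound 2, made on the methoxy core rather than the methyl core; the surroundings of the place are the same in both pairs. Within the data shown here, only one measured example of the change exists, so the expectation for compound 4 rests on it alone: the step is estimated as a 1.7-fold higher number from compound 3 to compound 4 (0.23 log units; within the scatter), set beside a 1.9-fold higher number from compound 1 to compound 2 (0.27 log units; within the scatter). Compound 4 is accordingly expected to give about 30000 nM in this assay, with a range from 12000 nM to 75000 nM.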

Compound 4, half-maximal inhibitory concentration: 4960 nM
The estimate for compound 4 lay 6.0-fold (0.78 log units) above the measured number; measured number outside the range, below it.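

In this assay, 3-aminophenyl in place of 4-aminophenyl gives a 3.6-fold lower number from compound 3 to compound 4 (0.55 log units; beyond the scatter), so the step does not carry over from the core of compound 1 to the core of compound 3 in either size or direction: the same change on two cores in this assay, a 1.9-fold higher number (0.27 log units; within the scatter) from compound 1 to compound 2 and a 3.6-fold lower number (0.55 log units; beyond the scatter) from compound 3 to compound 4, 6.8-fold (0.83 log units) apart, beyond the scatter of two such steps. Read the other way round, methoxy in place of methyl gives a 2.1-fold lower number from compound 2 to compound 4 (0.33 log units; beyond the scatter), so that change also depends on which aminophenyl group is present: the same change on two cores in this assay, a 3.2-fold higher number (0.50 log units; beyond the scatter) from compound 1 to compound 3 and a 2.1-fold lower number (0.33 log units; beyond the scatter) from compound 2 to compound 4, 6.8-fold (0.83 log units) apart, beyond the scatter of two such steps. These two readings come from the same four compounds and form a single case of the two changes failing to add up; they do not show why this happens or whether it holds beyond these compounds.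

On these data alone, whether the reversal persists with other groups on the sulfonyl-bearing ring, such as chloro or ethoxy, remains open. Also open, as far as these compounds go, is how a hydroxyl or a carboxylic acid in place of the amine on the aminophenyl ring would behave on either core.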